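The compounds below may be only part of what the source reports. "The series", "measured", "known", "first", "only" and "open" are said of these compounds alone.

Values in a functional assay on SMMC-7721 cells (Homo sapiens) for cytotoxicity, read by MTT assay, with a stated time of 24 h; on this read-out higher numbers stand for weaker inhibition and lower numbers for stronger inhibition:
compound 1 `CN1C/C(=C\c2ccncc2)C(=O)/C(=C/c2ccccc2C(F)(F)F)C1`: 4100 nM
compound 2 `O=C1/C(=C/c2ccncc2)CNC/C1=C\c1ccccc1C(F)(F)F`: 4500 nM

In this assay, compound 2 cannot be separated from compound 1. Among the measured compounds shown here, the only measured step, a 1.1-fold higher number from compound 1 to compound 2 (0.04 log units; within the scatter), puts hydrogen in place of methyl on an amine nitrogen in a ring. Compound 3 `Cc1ccc(S(=O)(=O)N2C/C(=C\c3ccncc3)C(=O)/C(=C/c3ccccc3C(F)(F)F)C2)cc1` changes that same place: (4-methylphenyl)sulfonyl in place of hydrogen on an amine nitrogen in a ring. For the measured compounds named here, this single step is a thin guide, as (4-methylphenyl)sulfonyl is a far larger group than methyl and no measured compound carries it. The data therefore set no direction for the change. Going by these compounds, the expected size is a 1.3-fold lower number from compound 2 to compound 3 (0.11 log units; within the scatter), so no step beyond the scatter is expected, although a larger step either way remains open. Compound 3 is estimated at 3500 nM, with an expected range of 1000 nM to 12000 nM.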

Compound 3, half-maximal inhibitory concentration: 5590 nM
Compound 3: middle estimate off by 1.6-fold (0.20 log units), on the low side; low and high end bracket the measured number.
By their numbers in this assay, from the lowest: compounds 1, 2 and 3 (each within the scatter of the next).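

In this assay, the amine nitrogen in the ring shows no response to a much larger group: the steps are a 1.2-fold higher number from compound 2 to compound 3 (0.09 log units; within the scatter) and a 1.4-fold higher number from compound 1 to compound 3 (0.13 log units; within the scatter). Compounds 1 and 2 covered only methyl and hydrogen at this place, whereas compound 3 extends the flat range to (4-methylphenyl)sulfonyl, which brings a six-membered aromatic ring of carbon only. No measurement available here accounts for this flat response.

The compounds shown leave open whether a benzyl group, an acetyl group or a chain ending in a carboxylic acid on the same nitrogen would give a step beyond the scatter. They also cannot show how much changes elsewhere on the shared core would matter, as all three compounds keep it unchanged.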